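Restoring an Aryl Group on the Ring Nitrogen

The compounds below may be only part of what the source reports. "The series", "measured", "known", "first", "only" and "open" are said of these compounds alone.

Measured compounds:
compound 1 `COc1ccc(-n2nc(Nc3cc(C)[nH]n3)c3ccccc3c2=O)cc1` — 3600 nM
compound 2 `Cc1cc(Nc2nn(C)c(=O)c3ccccc23)n[nH]1` — > 30000 nM

In a functional assay on MCF7 cells (Homo sapiens) for cytotoxicity (a lower number here means a stronger inhibitor, a higher number a weaker inhibitor), compound 1 gives 3600 nM. For compound 2 the assay reports only a limit, > 30000 nM, and not a number. Compound 2 thus stands at the weak end of the two values shown. For the measured compounds named here, the only measured step, an at least 8.3-fold higher number from compound 1 to compound 2 (0.92 log units; beyond the scatter), cannot be sized fully because the limit of > 30000 nM in this assay, at which 1 of the 2 values shown sits, caps what the assay reads.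

Compound 3 `Cc1cc(Nc2nn(Cc3ccc([N+](=O)[O-])cc3)c(=O)c3ccccc23)n[nH]1` differs from compound 2 by 4-nitrophenyl in place of hydrogen on a saturated chain carbon bound to an aromatic nitrogen. That change puts an aromatic ring back near the ring nitrogen, roughly undoing the loss that made compound 2 weak. On this basis the expected step of an at least 5.0-fold lower number from compound 2 to compound 3 (0.69 log units; beyond the scatter) points toward a lower number, though the new ring is attached through a chain carbon and carries a nitro group rather than a methoxy group, so compound 1 is only a loose guide. Compound 3 is estimated at 6000 nM, with a range from 1500 nM to 30000 nM.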

Compound 3, half-maximal inhibitory concentration: > 30000 nM
Compound 3 gave a limit, no number (the forecaster's own chance of this, stated with the estimate: 25%); middle value at least 5.0-fold (0.69 log units) from the limit.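

Compound 2 and compound 3 both end at a limit rather than a number, so no step between them can be read: the limit of > 30000 nM in this assay, at which 2 of the 3 values shown sit.

The compounds shown leave open whether 4-nitrophenyl in place of hydrogen on that saturated chain carbon changes the result at all.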